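Methylation of the ring nitrogen in a weak antiproliferative series

The source may report more compounds than this note shows. Statements on the series, on what has been measured and on what is new or still open speak of the compounds shown alone.

Measured compounds:
compound 1 `c1ccc(N2CCN(c3ccnc4[nH]ccc34)CC2)cc1` — 23600 nM
compound 2 `Cn1ccc2c(NCc3ccccc3)ccnc21` — > 100000 nM

Among the compounds with values here, in a functional assay on HL-60 cells (Homo sapiens) for antiproliferative activity (on this read-out higher numbers stand for weaker inhibition and lower numbers for stronger inhibition), compound 1 gives 23600 nM, the only numerical value in the set. Compound 2 returns > 100000 nM, which is a limit of this assay and not a number, the case described by the limit of > 100000 nM in this assay, at which 1 of the 2 values shown sits. Within the data shown here, no step between measured compounds is available, so the two values of compound 1 and compound 2 show only that one is a number and the other a limit.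

Compound 3 `Cn1ccc2c(N3CCN(c4ccccc4)CC3)ccnc21` differs from compound 1 by methyl in place of hydrogen on an aromatic nitrogen. Among the measured compounds shown here, since no measured step informs this change, no direction beyond the scatter is expected with confidence in this assay; a modest weakening is considered possible. For compound 3 an inhibitory concentration of 40000 nM is expected, within 10000 nM to 150000 nM, meaning an estimated step of a 1.7-fold higher number from compound 1 to compound 3 (0.23 log units; within the scatter).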

Compound 3, half-maximal inhibitory concentration: > 100000 nM
Compound 3: no number, only a limit (the forecaster's own chance of this, stated with the estimate: 30%); at least 2.5-fold (0.39 log units) between middle value and limit.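

In this assay compound 3 gives > 100000 nM, which is a limit of the assay and not a number. Methyl in place of hydrogen on an aromatic nitrogen therefore gives an at least 4.2-fold higher number from compound 1 to compound 3 (0.62 log units; beyond the scatter), the first measured step in this series and one beyond the scatter, so in this pair the hydrogen on that nitrogen goes with the only numerical value. The step has a lower bound but no full size, and a further loss cannot be told from a much larger one, because compound 3 sits at the assay ceiling: the limit of > 100000 nM in this assay, at which 2 of the 3 values shown sit.

From the compounds shown here alone, whether an ethyl group, a longer chain or a chain ending in an amine on the same nitrogen would return a number remains open. Also open, going by these compounds, is whether the step holds on a core carrying another substituent, since this single pair supports no general rule.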